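Phenyl Gives Way to Cyclohexyl in a Ketone Series

A few compounds are considered here, and "the series" means these few. Any claim that something is new, unique, unknown or untested is made for them only; others in the source may bear on it.

Of the compounds shown here, two have so far been measured in an assay for displacement of a labelled ligand from 5-hydroxytryptamine receptor 4 (Homo sapiens), with a stated time of 60 min, tested at 1 uM; on this read-out lower numbers stand for less inhibition and higher numbers for more inhibition at the one concentration tested (going by the name of the read-out). Compound 1 `O=C(CCC1CCN(CC2CCCCC2)CC1)c1cc(Cl)c2[nH]ccc2c1` gives 100% in this assay, and compound 2 `O=C(CCC1CCN(Cc2ccccc2)CC1)c1ccc2[nH]ccc2c1` gives 90%. Compound 2 has the lower of the two numbers, but the gap to compound 1 is within the usual scatter, so the two values cannot be told apart. Going by the values given here, compound 1 and compound 2 also differ from each other in more than one place, so no single step separates them.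

Compound 3 `O=C(CCC1CCN(CC2CCCCC2)CC1)c1ccc2[nH]ccc2c1` has not yet been measured. It differs from compound 2 by one change: cyclohexyl in place of phenyl on a saturated chain carbon bound to an amine nitrogen in a ring. Among the compounds with values here, no measured pair shows this change on its own. The cyclohexylmethyl group that enters is, however, already present in compound 1, whose value in this assay lies within the scatter of that of compound 2.

On that basis the step of a number 5 percentage points higher from compound 2 to compound 3 (within the scatter) is expected to be small, with no direction beyond the scatter. Compound 3 is therefore estimated at 95%, with a likely range from 85% to 100%.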

Compound 3, a percentage reported as inhibition, at one concentration (the size of the read-out at that concentration, not a potency): 100%
For compound 3 the middle estimate is 5 percentage points below the measured one; measured number inside the range.
By their numbers in this assay, from the lowest: compounds 2, 1 and 3 (each within the scatter of the next).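

In this assay the swap of phenyl for cyclohexyl on a saturated chain carbon bound to an amine nitrogen in a ring now has a pair of its own, reading as a number 10 percentage points higher from compound 2 to compound 3 (within the scatter), so the aromatic and the non-aromatic ring of carbon only cannot be told apart at this position on this read-out. Compound 3 also gives the first single-place view of the chloro on an aromatic carbon: hydrogen in its place reads as no change at the digits printed from compound 1 to compound 3 (within the scatter), so with cyclohexylmethyl present the chloro makes no difference that this read-out can show. Nothing at hand offers a reason for either result.

These numbers give the size of the read-out at one concentration only, so compound 1, compound 2 and compound 3 could still differ from one another at another concentration. As far as these compounds go, whether a cyclopentylmethyl or pyridylmethyl group in place of cyclohexylmethyl, or a methoxy group in place of the chloro, would give a similar number in this assay also stays open.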